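The source may report more compounds than this note shows. Statements on the series, on what has been measured and on what is new or still open speak of the compounds shown alone.

Measured compounds:
compound 1 `CC(C)(C)c1cn(C[C@H](O)[C@H]2OC(=O)C(OCc3ccccc3)=C2OCc2ccccc2)nn1` 35800 nM
compound 2 `Cc1ccc(S(=O)(=O)NCc2cn(C[C@H](O)[C@H]3OC(=O)C(OCc4ccccc4)=C3OCc3ccccc3)nn2)cc1` 45800 nM
compound 3 `C[Si](C)(C)c1cn(C[C@H](O)[C@H]2OC(=O)C(OCc3ccccc3)=C2OCc2ccccc2)nn1` 56000 nM

Three compounds share a core and differ only in the group on one aromatic carbon of the shared core. In a functional assay on SW-620 cells (Homo sapiens) for antiproliferative activity, read by MTT assay, with a stated time of 72 h (on this read-out higher numbers stand for weaker inhibition and lower numbers for stronger inhibition), compound 1 gives 35800 nM, compound 2 gives 45800 nM and compound 3 gives 56000 nM. Compound 3 has the highest of the three numbers, but every step among them is small: a 1.3-fold higher number from compound 1 to compound 2 (0.11 log units; within the scatter), a 1.6-fold higher number from compound 1 to compound 3 (0.19 log units; within the scatter) and a 1.2-fold higher number from compound 2 to compound 3 (0.09 log units; within the scatter). None of these steps stands beyond the scatter, so the three compounds are not distinguished by these numbers.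

Compound 4 `COc1ccc(-c2cn(C[C@H](O)[C@H]3OC(=O)C(OCc4ccccc4)=C3OCc3ccccc3)nn2)cc1` is obtained from compound 3 by a group of 8 heavy atoms (7 carbon, 1 oxygen; one six-membered aromatic ring of carbon only) in place of a group of 4 heavy atoms (3 carbon, 1 silicon; no ring), on an aromatic carbon. Among the compounds with values here, no measured step introduces an aromatic ring directly on that carbon; the nearest comparison is compound 2, whose aromatic ring sits behind a linker and whose number lies within the scatter of compound 3. The three measured steps, all within the scatter, therefore give no reason to expect a step beyond the scatter in this assay for compound 4, and an expected step of a 1.2-fold lower number from compound 3 to compound 4 (0.09 log units; within the scatter) follows. Compound 4 is expected to give 45000 nM, between 15000 nM and 140000 nM.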

Compound 4, half-maximal inhibitory concentration: 58200 nM
For compound 4 the middle estimate is 1.3-fold (0.11 log units) below the measured one, within the range that was stated.
By their numbers in this assay, from the lowest: compounds 1, 2, 3 and 4 (each within the scatter of the next).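

In this assay, 4-methoxyphenyl puts an aromatic ring directly on the aromatic carbon of the five-membered ring, and all three new steps stay within the scatter: a 1.0-fold higher number from compound 3 to compound 4 (0.02 log units; within the scatter), a 1.3-fold higher number from compound 2 to compound 4 (0.10 log units; within the scatter) and a 1.6-fold higher number from compound 1 to compound 4 (0.21 log units; within the scatter). The earlier compounds shown here carried an aromatic ring at this position only behind a linker, in compound 2, so this result extends the flat picture to a directly attached ring, and compounds 1, 2, 3 and 4 remain undistinguished. No accompanying data bear on why this change leaves the number unresolved from the others.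

The compounds shown leave open whether an amine or a carboxylic acid on this carbon would give a step beyond the scatter in this assay. They also leave open what a hydroxyl group in place of either benzyloxy group on the shared core would do.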